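The compounds below may be only part of what the source reports. "The series", "measured", "known", "first", "only" and "open" are said of these compounds alone.

Measured in a functional assay (Mus musculus) for inhibition, with a stated time of 5 days; a lower number here means a stronger inhibitor, a higher number a weaker inhibitor:
- Compound 1 `O=Cc1cn(-c2ccc(O)cc2)nc1-c1cccc(O)c1`: 42000 nM
- Compound 2 `O=C(O)/C=C/c1cn(-c2ccc(O)cc2)nc1-c1ccccc1`: > 100000 nM, a limit and not a number

For the measured compounds named here, only two compounds have been tested so far, and neither gives strong inhibition. Compound 2 has no exact value, as it stands at the limit of > 100000 nM in this assay, at which 1 of the 2 values shown sits. Any comparison starting from compound 2 can therefore show a direction, but not a firm size.

The next compound to be tested is compound 3 `O=Cc1cn(-c2ccc(O)cc2)nc1-c1ccccc1`. It keeps the shared core of compound 2 but has formyl in place of 2-carboxyethenyl on an aromatic carbon. This leaves a smaller group on the ring, the same type of group that compound 1 carries.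

Compound 1 reaches a measurable 42000 nM with formyl at that place, so compound 3 is expected to give a real number in this assay and to be the stronger inhibitor of the pair. The expected change is an at least 2.2-fold lower number from compound 2 to compound 3 (0.34 log units; beyond the scatter), a modest gain at best. For compound 3 the estimated value is 45000 nM, with an expected range from 15000 nM to 100000 nM.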

Compound 3, half-maximal inhibitory concentration: > 100000 nM
Compound 3: only a limit was reported; the forecaster's own chance of this, stated with the estimate: 25%; at least 2.2-fold (0.34 log units) between middle value and limit.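

Formyl on this aromatic carbon does not by itself give a readable value: in this assay, compound 3 gives > 100000 nM, which is a limit and not a number. Hydrogen in place of hydroxy on an aromatic carbon gives an at least 2.3-fold higher number from compound 1 to compound 3 (0.37 log units; beyond the scatter), so within this pair the measurable inhibition goes with that hydroxy group, not with formyl alone. The change from 2-carboxyethenyl to formyl cannot be sized, because both compounds that carry these groups stand at the same limit: the limit of > 100000 nM in this assay, at which 2 of the 3 values shown sit.

It remains open whether the same hydroxy group would also bring a compound with 2-carboxyethenyl on the five-membered ring into the measurable range, since the compounds shown test that hydroxy group only alongside formyl. As far as these compounds go, it also remains open whether another group at this place, such as an amine or an amide, would give a lower number than the weak inhibition seen so far, and whether the hydroxy group on the phenyl ring could be replaced by a methoxy group.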